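The source may hold more compounds than are shown below. What is called first, only, known or untested is meant among the compounds shown, and "the series" means these compounds.

Working notes on the series. For the measured compounds named here, compound 1 `O=[N+]([O-])c1ccc2[nH]c(-c3cccnc3)cc2c1` stands second highest of the three numbers so far in an assay on isolated protein for inhibition of Aromatase (Homo sapiens), read by fluorescence, using NADPH, with a stated time of 30 min, tested at 50 uM; a higher number here means more inhibition at the concentration tested (going by the name of the read-out), a lower number less inhibition: compound 1 gives 27.9%, compound 2 `Clc1ccc2cc(-c3ccccc3)[nH]c2c1` gives 13.6%, and compound 3 `O=[N+]([O-])c1ccc2[nH]c(-c3ccccc3)cc2c1` gives 77.7%. Going by the values given here, the only step between measured compounds that differ in one place is a number 49.8 percentage points higher from compound 1 to compound 3 (beyond the scatter); it concerns the pyridin-3-yl and phenyl groups and says nothing about the nitro group.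

The change from compound 1 to the unmeasured compound 4 `c1cncc(-c2cc3ccccc3[nH]2)c1` is hydrogen in place of nitro on an aromatic carbon. Among the compounds with values here, no measured step bears directly on this change. The nearest comparison is the pair of compound 2 and compound 3, which share the phenyl group, compound 2 carrying chloro in place of the nitro of compound 3; compound 3 gives 77.7% and compound 2 gives 13.6%, so within this series the nitro group goes with the larger number. On that basis, and with only these three compounds to go on, the loss of the nitro group in compound 4 is expected to lower the inhibition beyond the scatter, with a step of a number 17.9 percentage points lower from compound 1 to compound 4 (beyond the scatter) expected. Compound 4 is therefore estimated at 10%, with a range from 0% to 30%.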

Compound 4, a percentage reported as inhibition, at one concentration (the size of the read-out at that concentration, not a potency): 81.6%
The estimate for compound 4 lay 71.6 percentage points below the measured number; measured number outside the range, above it.
By their numbers in this assay, from the lowest: compound 2; then compound 1; then compounds 3 and 4 (each within the scatter of the next).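

In this assay, for the compounds shown here, the first step at this position, hydrogen in place of nitro on an aromatic carbon of the six-membered aromatic ring of carbon only, is a number 53.7 percentage points higher from compound 1 to compound 4 (beyond the scatter), so with pyridin-3-yl kept in place, the nitro group is not required for a large number and its presence goes with the smaller one. The earlier single step, a number 49.8 percentage points higher from compound 1 to compound 3 (beyond the scatter), concerned only the other place of change, so this result adds a second large rise from compound 1, reached by removing a group rather than by exchanging one ring for another. No measurement on hand bears on the reason for this rise.

Whether the same change at this position gives a rise of similar size with phenyl in place of pyridin-3-yl stays open, as no pair of compounds shown tests it, and so does whether the two changes from compound 1 would add up. Also open, going by these compounds, is how an amine, a methoxy group or a carboxylic acid at this position would compare with hydrogen and nitro, since only those two groups can be compared here on the shared core.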